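The compounds below may be only part of what the source reports. "The series", "measured", "known", "first", "only" and "open" are said of these compounds alone.

Measured in a functional assay on BT-474 cells (Homo sapiens) for inhibition; on this read-out lower numbers stand for stronger inhibition and higher numbers for weaker inhibition:
- compound 1 `COc1c(C)cnc(CN2c3nc(N)nc(Cl)c3NC(=O)[C@@H]2CC(C)C)c1C`: 490 nM
- compound 2 `COc1ccnc(CN2CC(=O)N(CC(C)C)c3c(Cl)nc(N)nc32)c1OC`: 30 nM

Of these two numbers, compound 1 has the higher one, 490 nM, which makes it the weaker inhibitor of the pair. Compound 2 gives 30 nM, a gap beyond the usual scatter. The two structures differ in more than one place, so this gap cannot be tied to any single group.

Compound 3 `COc1c(C)cnc(CN2c3nc(N)nc(Cl)c3NC(=O)[C@@H]2C)c1C` keeps the core of compound 1 and changes one thing: hydrogen in place of isopropyl on a saturated chain carbon bound to a saturated ring carbon. This is hydrogen in place of isopropyl on a saturated chain carbon bound to a saturated ring carbon, which can also be read as isobutyl to methyl.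

Among the compounds with values here, no measured pair shows this change alone, so the data give no direct guide to its effect in this assay. A small move towards a higher number is expected, probably within the scatter, though a larger move in either direction remains possible. The estimated step is a 1.4-fold higher number from compound 1 to compound 3 (0.15 log units; within the scatter). Starting from compound 1 at 490 nM, the expected value for compound 3 is 700 nM, with an estimated range of 180 nM to 2500 nM.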

Compound 3, half-maximal inhibitory concentration: 470 nM
Estimate against measurement, compound 3: 1.5-fold (0.17 log units) above; the measured number falls inside the stated range.
By their numbers in this assay, from the lowest: compound 2; then compounds 3 and 1 (each within the scatter of the next).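

In this assay, going from isobutyl to methyl on this saturated ring carbon gives a 1.0-fold lower number from compound 1 to compound 3 (0.02 log units; within the scatter) and so leaves the two compounds indistinguishable on this read-out. Within the data shown here, this is the first direct reading at this position: with the core of compound 1 held fixed, isopropyl, with its 3 heavy atoms, can give way to hydrogen with no difference beyond the scatter, so in this pair the outer part of the chain has no visible bearing on the number. Nothing measured here says why the two numbers match.

On these data alone, whether the position tolerates any group equally stays open, since an amine, a carboxylic acid or a longer chain on the same carbon could still move the number in either direction. The gap to compound 2 also remains unassigned, as that compound differs from compound 1 and from compound 3 in more than one place, and the present pair says nothing about which of those differences matters.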